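The source may report more compounds than this note shows. Statements on the series, on what has been measured and on what is new or still open speak of the compounds shown alone.

In a functional assay on the whole organism for inhibition, with Rattus norvegicus as the target, read by cytopathic effect and paw edema, at a dose of 100 mg/kg by the oral route (on this read-out lower numbers stand for less inhibition and higher numbers for more inhibition at the one dose given (going by the name of the read-out)), compound 3 `O=C(Nc1cccc([N+](=O)[O-])c1)c1c(O)c2cccnc2n(-c2ccccc2)c1=O` gives 7.4%, the highest of the three numbers recorded, though neither gap to its neighbours is beyond the scatter: compound 2 `O=C(Nc1ccc(Cl)cc1)c1c(O)c2cccnc2n(-c2ccccc2)c1=O` gives 2.5%, and compound 1 `Cc1ccc(NC(=O)c2c(O)c3cccnc3n(-c3ccccc3)c2=O)cc1` gives 2.2%. Compound 4 `Cc1ccccc1NC(=O)c1c(O)c2cccnc2n(-c2ccccc2)c1=O` has not been measured; it differs from compound 3 by 2-methylphenyl in place of 3-nitrophenyl on an amide-type nitrogen. Among the compounds with values here, two measured steps bear on this change, both being swaps of the aryl group on the amide-type nitrogen: a number 5.2 percentage points higher from compound 1 to compound 3 (within the scatter) and a number 4.9 percentage points higher from compound 2 to compound 3 (within the scatter). The remaining step, a number 0.3 percentage points higher from compound 1 to compound 2 (within the scatter), also stayed within the scatter. Nothing among these compounds shows the aryl group moving the inhibition beyond the scatter, so compound 4 is expected to stay near compound 3. The expected step is a number 3.4 percentage points lower from compound 3 to compound 4 (within the scatter). Compound 4 is therefore estimated at 4%, between 0% and 11%.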

Compound 4, a percentage reported as inhibition, in the whole organism at one dose (the size of the read-out at that dose, not a potency): 9.8%
Compound 4: the middle estimate sits 5.8 percentage points below what was measured; low and high end bracket the measured number.
By their numbers in this assay, from the lowest: compounds 1, 2, 3 and 4 (each within the scatter of the next).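

With 2-methylphenyl on the amide-type nitrogen, the change in this assay is a number 2.4 percentage points higher from compound 3 to compound 4 (within the scatter), while the swaps from the other aryl groups give a number 7.3 percentage points higher from compound 2 to compound 4 (within the scatter) and a number 7.6 percentage points higher from compound 1 to compound 4 (within the scatter). The aryl group can thus lose its nitro group, and 2-methylphenyl can replace 4-methylphenyl, without any step leaving the scatter. Nothing shown explains these numbers.

The compounds shown leave open whether an amine, a carboxylic acid or a longer alkyl chain in place of this aryl group would go beyond the scatter. They also leave open whether changes elsewhere on the shared core would do so.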